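Demethylation on oxygen in a weak nicotinic series

This account rests on a few compounds, and the source may have more. Where it says the series, first, only, none or still open, it means among the compounds named here.

Within the data shown here, in an assay on HEK293 cells for displacement of a labelled ligand from Neuronal acetylcholine receptor; alpha4/beta4 (Rattus norvegicus), with a stated time of 4 h (a lower number here means a stronger inhibitor, a higher number a weaker inhibitor), compound 2 `CO[C@H]1CC=C2CCN(C)[C@H]2C1` gives 100000 nM, the only actual number in the set. Compound 1 `CCO[C@H]1CC[C@H]2CCN(C)[C@H]2C1` reaches only the limit > 300000 nM. Compound 3 `CO[C@H]1CC=C2CCN[C@H]2C1` likewise reaches only the limit > 300000 nM. Compound 1 and compound 2 differ in two places, so their values are simply set side by side, one a number and one a limit. Among the measured compounds shown here, the single one-point step measured is an at least 3.0-fold higher number from compound 2 to compound 3 (0.47 log units; beyond the scatter), which places compound 3 at the limit of > 300000 nM in this assay, at which 2 of the 3 values shown sit.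

Compound 4 `CN1CCC2=CC[C@H](O)C[C@@H]21` differs from compound 2 by hydrogen in place of methyl on an oxygen on a saturated carbon; read one bond further out, methoxy becomes hydroxy. For the measured compounds named here, no measured step removes a methyl from oxygen; the only demethylation seen is the one on the ring amine nitrogen, and its size is known only as a lower bound because compound 3 sits at the limit of > 300000 nM in this assay, at which 2 of the 3 values shown sit. That step bears on the present one only through the group removed, not the place. The expectation in this assay is therefore a step toward similar or weaker binding, with a real chance that only a limit is reported.

Compound 4 is estimated at 150000 nM, with a range from 40000 nM to 600000 nM. That estimate means an expected step of a 1.5-fold higher number from compound 2 to compound 4 (0.18 log units; within the scatter).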

Compound 4, inhibition constant: > 300000 nM
Compound 4 ended at the assay's limit (the forecaster's own chance of this, stated with the estimate: 40%); middle value at least 2.0-fold (0.30 log units) from the limit.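

Removing the methyl from the oxygen on a saturated carbon, methoxy to hydroxy, now has a measured step of its own in this assay: an at least 3.0-fold higher number from compound 2 to compound 4 (0.47 log units; beyond the scatter). On these data alone, compound 4 gives > 300000 nM, which is a limit of the assay and not a number, so this step is a lower bound and its true size stays unknown. The methyl on this oxygen therefore joins the methyl on the amine nitrogen in a ring, whose removal gave an at least 3.0-fold higher number from compound 2 to compound 3 (0.47 log units; beyond the scatter), as a group whose loss from compound 2 leaves no measurable value, and the two steps cannot be ranked against each other since both end at the same limit: the limit of > 300000 nM in this assay, at which 3 of the 4 values shown sit.

Among these compounds, it remains open whether any change at this oxygen can give a lower number than compound 2 does at 100000 nM, the only actual value in the set. A longer chain such as propyl on the oxygen, or an amine in place of the methoxy, would show whether this position tolerates anything other than methoxy.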